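Lactam to open amino acid at the amide nitrogen

A few compounds are considered here, and "the series" means these few. Any claim that something is new, unique, unknown or untested is made for them only; others in the source may bear on it.

Measured compounds:
compound 1, `CCCCCCCCN(CCCCCCCC)[C@H](CCC(=O)NC(CCCC(N)C(=O)O)C(=O)O)C(=O)O`: 0.2 nM
compound 2, `CCCCCCCCCCCOC(=O)[C@@H](CCC(=O)NC(CCCC(N)C(=O)O)C(=O)O)NC(=N)N`: 0.238 nM
compound 3, `CCCCCCCCCCCC(=O)N[C@H](CCC(=O)NC1CCCCNC1=O)C(=O)O`: 1.73 nM

All three were run in a functional assay on HEK293 cells for agonist activity at Nucleotide-binding oligomerization domain-containing protein 1 (Homo sapiens), read by spectrophotometry; on this read-out higher numbers stand for an effect only at larger amounts of compound and lower numbers for an effect already at smaller amounts. Compound 3 gives the highest of the three numbers; it stands beyond the scatter from both compound 2, the nearest, and compound 1, the furthest. Nothing else about steps among these three is known, so only the values themselves are compared here.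

Compound 4 is `CCCCCCCCCCCC(=O)N[C@H](CCC(=O)NCCCC[C@H](N)C(=O)O)C(=O)O` and has not been measured. It differs from compound 3 in one place: 5-amino-5-carboxypentyl in place of 2-oxoazepan-3-yl on an amide-type nitrogen. The entering group carries two hydrogen-bond donors and two acceptors and one defined stereocentre, where the leaving group carried one of each and a seven-membered ring.

Going by the values given here, no measured pair shows this change, so the size of the step cannot be read from the data. The expectation is that the step from compound 3 to compound 4 in this assay stays within the usual scatter, a 1.2-fold lower number from compound 3 to compound 4 (0.06 log units; within the scatter). For compound 4 the estimated value in this assay is 1.5 nM, with a range from 0.4 nM to 6 nM.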

Compound 4, half-maximal effective concentration: 0.96 nM
The estimate for compound 4 lay 1.6-fold (0.19 log units) above the measured number; the measured number falls inside the stated range.
By their numbers in this assay, from the lowest: compounds 1 and 2 (each within the scatter of the next); then compounds 4 and 3 (each within the scatter of the next).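

Working notes on the amide-type nitrogen: in this assay this is the first measured single-place change at this position, and 5-amino-5-carboxypentyl in place of 2-oxoazepan-3-yl gives a 1.8-fold lower number from compound 3 to compound 4 (0.26 log units; within the scatter). In this one pair, the seven-membered ring can therefore give way to an open chain with a defined stereocentre and added hydrogen-bond donors and acceptors without a shift beyond the scatter. No supporting evidence bears on why the step is this small.

Still open, as far as these compounds go, is whether both the amine and the carboxylic acid of the entering group are needed, which a plain pentyl group on the same nitrogen would test. The opposite configuration at the defined stereocentre, and a shorter or longer chain linking the amino acid to this nitrogen, also remain to be placed.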